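The source may report more compounds than this note shows. Statements on the series, on what has been measured and on what is new or still open speak of the compounds shown alone.

Compound 3 `FC(F)(F)c1cc(C2CO2)cc(C(F)(F)F)c1` carries the oxiran-2-yl group on the shared core. In an ADME assay for pharmacokinetics, read by LC-MS, in phosphate buffer, with a stated time of 72 h, at pH 7.4, tested at 250 uM (on this read-out higher numbers stand for a longer-lived compound and lower numbers for a shorter-lived compound), compound 3 gives > 50 h, which is a limit of the assay and not a number. Compound 1 `C=Cc1cc(C(F)(F)F)cc(C(F)(F)F)c1` gives > 50 h, also a limit. Compound 2 `C#Cc1cc(C(F)(F)F)cc(C(F)(F)F)c1` gives > 50 h, again a limit. All three values sit at the limit of > 50 h in this assay, at which 3 of the 3 values shown sit, so the steps a step that the two limits leave unreadable from compound 1 to compound 2, a step that the two limits leave unreadable from compound 1 to compound 3 and a step that the two limits leave unreadable from compound 2 to compound 3 cannot be sized, and compound 3 stands at the limit together with the other two. Compound 4 `FC(F)(F)c1cc(S)cc(C(F)(F)F)c1` differs from compound 3 by sulfanyl in place of oxiran-2-yl on an aromatic carbon. No measured step involves the sulfanyl group, and the three steps that are known are unreadable, so no size or direction can be derived for the step to compound 4 in this assay from the numbers shown. With nothing pointing either way, the change is taken as none beyond the scatter, with wide uncertainty. On that footing compound 4 is expected to give 50 h in this assay, with a likely range from 8 h to 150 h. For compound 4 the expected step is a number no higher from compound 3 to compound 4 (the limit leaves the size open).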

Compound 4, half-life: > 50 h
Compound 4: only a limit was reported; the forecaster's own chance of this, stated with the estimate: 50%; the middle value sits exactly at the limit.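

The steps from compound 1, compound 2 and compound 3 to compound 4 cannot be read in this assay, as each value is a limit of the assay: the limit of > 50 h in this assay, at which 4 of the 4 values shown sit.

The compounds shown leave open how the half-lives of these four compounds compare and whether any group on the shared core separates them.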